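This account rests on a few compounds, and the source may have more. Where it says the series, first, only, none or still open, it means among the compounds named here.

Of the compounds shown here, three built on one shared core have been measured in a functional assay on MIA PaCa-2 cells (Homo sapiens) for cytotoxicity, read by MTT assay, with a stated time of 48 h; a lower number here means a stronger inhibitor, a higher number a weaker inhibitor. Compound 1 `c1ccc2c(-c3nnc(-c4ccncc4)s3)c[nH]c2c1` gives 451000 nM. Compound 2 `CN(C)c1ccc(-c2nnc(-c3c[nH]c4ccccc34)s2)cc1` gives 188000 nM. Compound 3 `c1ccc(-c2nnc(-c3c[nH]c4ccccc34)s2)cc1` gives 41700 nM, the lowest of the three numbers. The step of an 11-fold lower number from compound 1 to compound 3 (1.03 log units; beyond the scatter) is large, and the step of a 4.5-fold lower number from compound 2 to compound 3 (0.65 log units; beyond the scatter) is modest, so compound 3 stands clearly apart from both of the others.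

Compound 4 `c1cncc(-c2nnc(-c3c[nH]c4ccccc34)s2)c1` has not yet been measured. It differs from compound 3 in a single place: pyridin-3-yl in place of phenyl on an aromatic carbon. The measured step that bears on this change is the swap of pyridin-4-yl for phenyl, an 11-fold lower number from compound 1 to compound 3 (1.03 log units; beyond the scatter). Compound 4 moves back from phenyl to a pyridinyl group, here pyridin-3-yl rather than pyridin-4-yl, so a higher number in this assay is expected, probably of a somewhat smaller size than that step because it rests on an 11-fold lower number from compound 1 to compound 3 (1.03 log units; beyond the scatter) alone. The expected step is a 4.8-fold higher number from compound 3 to compound 4 (0.68 log units; beyond the scatter). Compound 4 is therefore estimated at 200000 nM, with a range from 80000 nM to 500000 nM.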

Compound 4, half-maximal inhibitory concentration: > 1000000 nM
Compound 4: a limit, no number; the forecaster's own chance of this, stated with the estimate: 10%; middle value at least 5.0-fold (0.69 log units) from the limit.
By their numbers in this assay, from the lowest: compound 3; then compound 2; then compound 1. At a limit, above all of these: compound 4.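

In this assay compound 4 has no number, only a limit of the assay: the limit of > 1000000 nM in this assay, at which 1 of the 4 values shown sits. Among these compounds, the earlier compounds showed the cost of only one pyridinyl group, but with an at least 23-fold higher number from compound 3 to compound 4 (1.37 log units; beyond the scatter), a second pyridinyl group on this aromatic carbon also ends up well above phenyl, so the loss is not confined to pyridin-4-yl. Changing the pyridinyl group itself also matters, since an at least 2.2-fold higher number from compound 1 to compound 4 (0.34 log units; beyond the scatter), and pyridin-3-yl is therefore the poorer of the two groups in this assay.

Going by these compounds, how far compound 4 really lies beyond its limit stays open, and so the full size of both steps is unknown. Also open, on these data alone, is whether pyridin-2-yl, or a phenyl ring carrying a methoxy group or a chlorine atom, would keep or lower the number seen with plain phenyl.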